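From 2-methylphenyl to furan-2-yl on a shared core

A few compounds are considered here, and "the series" means these few. Any claim that something is new, unique, unknown or untested is made for them only; others in the source may bear on it.

Of the compounds shown here, three sharing one core have been measured in a functional assay on PC-3 cells (Homo sapiens) for cytotoxicity; on this read-out lower numbers stand for an effect already at smaller amounts and higher numbers for an effect only at larger amounts of compound. There compound 1 `COC1=C(C)C(=O)/C(=C(O)/C=C/c2ccc(OC)cc2)C(=O)C1(C)C` gives 18.2 ug/mL, compound 2 `COC1=C(C)C(=O)/C(=C(O)/C=C/c2ccccc2OC)C(=O)C1(C)C` gives 15.6 ug/mL, and compound 3 `COC1=C(C)C(=O)/C(=C(O)/C=C/c2ccccc2C)C(=O)C1(C)C` gives 9 ug/mL. Compound 3 stands apart from compound 1 only, since a 2.0-fold lower number from compound 1 to compound 3 (0.31 log units; beyond the scatter) is a modest step beyond the scatter, while a 1.7-fold lower number from compound 2 to compound 3 (0.24 log units; within the scatter) stays within it.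

Compound 4 `COC1=C(C)C(=O)/C(=C(O)/C=C/c2ccco2)C(=O)C1(C)C` has not yet been measured. It carries furan-2-yl in place of 2-methylphenyl on a double-bonded chain carbon bound to a double-bonded chain carbon.

For the measured compounds named here, no measured compound carries this furan-2-yl group, so no step tests the change directly. The nearest evidence is the exchange of groups at this same place, where a 1.2-fold lower number from compound 1 to compound 2 (0.07 log units; within the scatter) lies within the scatter and a 2.0-fold lower number from compound 1 to compound 3 (0.31 log units; beyond the scatter) only just passes it. A small move towards a higher number, within the scatter, is therefore expected in this assay, and the estimated step is a 1.6-fold higher number from compound 3 to compound 4 (0.19 log units; within the scatter). For compound 4 the estimated value is 14 ug/mL, with an expected range from 6 ug/mL to 30 ug/mL.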

Compound 4, concentration for half-maximal effect: 20.6 ug/mL
Estimate against measurement, compound 4: 1.5-fold (0.17 log units) below; the measured number falls inside the stated range.
By their numbers in this assay, from the lowest: compounds 3, 2, 1 and 4 (each within the scatter of the next, the first and the last beyond it).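

With furan-2-yl, the group on a double-bonded chain carbon bound to a double-bonded chain carbon is no longer a substituted phenyl, yet in this assay the result stays close to both methoxyphenyl compounds, with a 1.3-fold higher number from compound 2 to compound 4 (0.12 log units; within the scatter) and a 1.1-fold higher number from compound 1 to compound 4 (0.05 log units; within the scatter). The change registers only against 2-methylphenyl, with a 2.3-fold higher number from compound 3 to compound 4 (0.36 log units; beyond the scatter), a modest step that sets compound 3 apart from compound 4 as well as from compound 1, while compound 2 remains within the scatter of all three. No evidence on the cause of this step is at hand.

On these data alone, all four compounds carry an aromatic ring at this place, so it remains open how an amine, a carboxylic acid or a longer alkyl chain there would read out in this assay. As far as these compounds go, it is also open whether a thiophene or pyridine ring would stay with compound 4 or move towards compound 3.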